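From Branched to Straight Chain on the Amine Nitrogen

This account rests on a few compounds, and the source may have more. Where it says the series, first, only, none or still open, it means among the compounds named here.

Among the measured compounds shown here, compound 2 `COc1cc(/C=C/C(=O)/C=C(/C=C/c2ccc(O)c(OC)c2)NCC(C)C)ccc1O` stands at the low end of the two numbers so far: in a functional assay on EA.hy 926 cells (Homo sapiens), read by fluorescence, tested at 1 uM (on this read-out lower numbers stand for a weaker effect and higher numbers for a stronger effect at the one concentration tested), compound 2 gives 83%, while compound 1 `C=CCNC(=C\C(=O)/C=C/c1ccc(O)c(OC)c1)/C=C/c1ccc(O)c(OC)c1` gives 124%. For the measured compounds named here, the only step measured between them, a number 41 percentage points lower from compound 1 to compound 2 (beyond the scatter), came from isopropyl in place of vinyl on a saturated chain carbon bound to an amine nitrogen. Compound 3 `CCCCNC(=C\C(=O)/C=C/c1ccc(O)c(OC)c1)/C=C/c1ccc(O)c(OC)c1` is the next member, and it differs from compound 2 by propyl in place of isopropyl on a saturated chain carbon bound to an amine nitrogen. Going by the values given here, the one measured step concerns a different exchange and cannot be read onto a rearrangement in which the two compounds have the same atoms, joined differently; no measured pair shows what moving from isopropyl to propyl does here. With nothing in the data pointing one way, the expectation for compound 3 is a step of a number 2 percentage points higher from compound 2 to compound 3 (within the scatter), which stays within the scatter. Among the compounds with values here, compound 3 is therefore estimated at 85% in this assay, with a range from 55% to 115% that allows for a change no measured step covers.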

Compound 3, a percentage reported as activity, at one concentration (the size of the read-out at that concentration, not a potency): 110%
Compound 3: the middle estimate sits 25 percentage points below what was measured; measured number inside the range.
By their numbers in this assay, from the lowest: compound 2; then compound 3; then compound 1.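

In this assay the exchange on a saturated chain carbon bound to an amine nitrogen is not silent, even though the atoms stay the same and only their joining differs: propyl in place of isopropyl gives a number 27 percentage points higher from compound 2 to compound 3 (beyond the scatter) and so separates the isobutylamino and butylamino forms of the shared core. The unbranched chain still does not match the compound with vinyl in that place, as the other new step reads a number 14 percentage points lower from compound 1 to compound 3 (beyond the scatter) and leaves compound 1 highest of the three, with compound 2 lowest and compound 3 in the middle. Nothing on hand accounts for either difference.

The compounds shown leave open whether the number keeps moving as the unbranched chain changes in length, for instance with an ethyl or a pentyl group on the amine nitrogen. They also do not say whether the vinyl compound's standing belongs to that end group in particular, which a propargyl group or a terminal hydroxyl on the same chain could begin to test.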